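A few compounds are considered here, and "the series" means these few. Any claim that something is new, unique, unknown or untested is made for them only; others in the source may bear on it.

In a physicochemical assay for lipophilicity, measured as octanol-water partition, at pH 7.4 (on this read-out higher numbers stand for higher lipophilicity and lower numbers for lower lipophilicity), two compounds have been measured so far. Compound 1 (`Cc1ccc2[nH]c(C(=O)N[C@H]3CN(S(=O)(=O)c4ccnc(C)c4)C[C@@H]3C(=O)NCCN(C)C)cc2c1`) gives 1.7, and compound 2 (`Cc1ccc2[nH]c(C(=O)N[C@H]3CCN(S(=O)(=O)c4cccnc4)C[C@@H]3C(=O)NCCN(C)C)cc2c1`) gives 1.3. Compound 2 therefore holds the lower of the two numbers, and its gap to compound 1 lies beyond the usual scatter of repeated measurements.

Compound 3 (`Cc1ccc2[nH]c(C(=O)N[C@H]3CCN(S(=O)(=O)N4CCCCC4)C[C@@H]3C(=O)NCCN(C)C)cc2c1`) has not yet been measured. It differs from compound 2 in one place, with piperidin-1-yl in place of pyridin-3-yl on a sulfonyl sulfur. A six-membered aromatic ring thus gives way to a six-membered non-aromatic ring, while the heavy-atom count stays the same.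

Within the data shown here, no two measured compounds differ in one place only, so no measured step speaks directly to this change, and the expectation rests on the structural change alone. The change in this assay is expected to be upward and beyond the scatter, with an estimated step of a number 0.60 log units higher from compound 2 to compound 3 (beyond the scatter). For compound 3 the estimated value is 1.9, with an expected range from 1.5 to 2.3.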

Compound 3, distribution coefficient: 2.3
Compound 3: middle estimate off by 0.40 log units, on the low side; low and high end bracket the measured number.
By their numbers in this assay, from the lowest: compound 2; then compound 1; then compound 3.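

Piperidin-1-yl in place of pyridin-3-yl on a sulfonyl sulfur gives a number 1.00 log units higher from compound 2 to compound 3 (beyond the scatter) in this assay and is the only step shown between compounds that differ in one place. It shows that this position, on a sulfonyl sulfur whose other neighbour is a sulfonamide nitrogen in a ring, can move the read-out beyond the scatter even when the heavy-atom count stays the same. The swap changes two counted features, replacing an aromatic ring with a non-aromatic one and removing a hydrogen-bond acceptor, but no measurement here ties the step to either feature or gives a reason for its size.

The compounds shown leave open which of those two features goes with the step, and a cyclohexyl or phenyl group on the same sulfonyl sulfur would help to pull them apart. They also leave open whether a step of this size would recur with morpholin-4-yl at this position, or with the same swap on the core of compound 1.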